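The source may report more compounds than this note shows. Statements on the series, on what has been measured and on what is new or still open speak of the compounds shown alone.

Compound 1 `CC1=CC[C@H](C(C)(C)NC(=S)N/N=C/c2ccccc2)CC1` — in an ADME assay on Vero cells (Chlorocebus sabaeus) for inhibition, read by sulforhodamine B assay, with a stated time of 48 h (a lower number here means a stronger inhibitor of growth, a higher number a weaker inhibitor of growth), compound 1 gives > 100000 nM, a limit of the assay.
Compound 2 `COc1ccc(/C=N/NC(=S)NC(C)(C)[C@H]2CC=C(C)CC2)cc1` — in this assay compound 2 gives 70100 nM.
Compound 3 `CC1=CC[C@H](C(C)(C)NC(=S)N/N=C/c2ccc(O)cc2)CC1` — in this assay compound 3 gives > 100000 nM, a limit of the assay.

Compound 3 stands only at a limit, and the limit of > 100000 nM in this assay, at which 2 of the 3 values shown sit, covers it. Compound 4 `CC1=CC[C@H](C(C)(C)NC(=S)N/N=C/c2ccc(N(C)C)cc2)CC1` differs from compound 3 by dimethylamino in place of hydroxy on an aromatic carbon. Within the data shown here, the steps that bear on this position are a step that the two limits leave unreadable from compound 1 to compound 3, an at least 1.4-fold higher number from compound 2 to compound 3 (0.15 log units; that floor lies within the scatter) and an at least 1.4-fold lower number from compound 1 to compound 2 (0.15 log units; that floor lies within the scatter); none of them gives a readable size beyond the scatter. No step beyond the scatter is therefore expected in this assay in either direction, and the step from compound 3 to compound 4 is estimated as an at least 1.1-fold lower number from compound 3 to compound 4 (0.07 log units; that floor lies within the scatter). For compound 4 the expected value is 85000 nM, with a range from 30000 nM to 200000 nM.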

Compound 4, concentration for total growth inhibition: > 100000 nM
Compound 4: a limit, no number (the forecaster's own chance of this, stated with the estimate: 55%); at least 1.1-fold (0.07 log units) between middle value and limit.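

Dimethylamino on the aromatic carbon para to a large group gives a third substituent at the ceiling in this assay: compound 4 gives > 100000 nM, a limit. Dimethylamino in place of methoxy gives an at least 1.4-fold higher number from compound 2 to compound 4 (0.15 log units; that floor lies within the scatter), so compound 2 still cannot be told apart from the others beyond the scatter. The steps to compound 4 from compound 1 and from compound 3 cannot be read, with both ends of each at a limit: the limit of > 100000 nM in this assay, at which 3 of the 4 values shown sit.

Going by these compounds, whether any group here brings a clear gain stays open. A carboxylic acid, a primary amine or a longer alkoxy chain at this place would test that.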